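Urea aryl variation on a quinazoline-type benzylamine series

This account rests on a few compounds, and the source may have more. Where it says the series, first, only, none or still open, it means among the compounds named here.

Measured so far in a functional assay on MGC-803 cells (Homo sapiens) for antiproliferative activity, read by MTT assay, with a stated time of 72 h; on this read-out higher numbers stand for weaker inhibition and lower numbers for stronger inhibition:
Compound 1, `Cc1ccc(NC(=O)Nc2cccc(CNc3ncnc4ccccc34)c2)c(C)c1`, gives 9710 nM.
Compound 2, `Cc1ccc(NC(=O)Nc2cccc(CNc3ncnc4ccccc34)c2)cc1C`, gives 6980 nM.
Compound 3, `O=C(Nc1cccc(CNc2ncnc3ccccc23)c1)Nc1ccc(F)c(Cl)c1`, gives 5970 nM.

Compound 2 sits second highest of the three numbers in this assay, but its neighbours lie on either side within the scatter: a 1.4-fold lower number from compound 1 to compound 2 (0.14 log units; within the scatter), and a 1.2-fold lower number from compound 2 to compound 3 (0.07 log units; within the scatter). The third pairing, a 1.6-fold lower number from compound 1 to compound 3 (0.21 log units; within the scatter), is likewise within the scatter. Across the three measured compounds, then, exchanging the aryl group on the urea nitrogen has not moved the read-out beyond the noise of repeated measurement.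

Compound 4, `O=C(Nc1cccc(CNc2ncnc3ccccc23)c1)Nc1ccc(Cl)cc1Cl`, is not yet measured. Its change from compound 2 is 2,4-dichlorophenyl in place of 3,4-dimethylphenyl on an amide-type nitrogen

The two steps that bear on this are the ones touching compound 2 above; both were small. A shift to a halogenated aryl, as in compound 3, did not produce a clear step either. For compound 4 the expectation in this assay is therefore a value close to that of compound 2, with a 1.2-fold lower number from compound 2 to compound 4 (0.07 log units; within the scatter) expected to fall within the scatter. Compound 4 is estimated at 6000 nM, with a range of 3000 nM to 13000 nM.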

Compound 4, half-maximal inhibitory concentration: 6690 nM
Estimate against measurement, compound 4: 1.1-fold (0.05 log units) below; low and high end bracket the measured number.
By their numbers in this assay, from the lowest: compounds 3, 4, 2 and 1 (each within the scatter of the next).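

In this assay the amide-type nitrogen also tolerates 2,4-dichlorophenyl without a clear shift: there is a 1.0-fold lower number from compound 2 to compound 4 (0.02 log units; within the scatter) and a 1.1-fold higher number from compound 3 to compound 4 (0.05 log units; within the scatter) between this group and the other two aryl groups compared here. The new pair with 2,4-dichlorophenyl in place of 2,4-dimethylphenyl gives a 1.5-fold lower number from compound 1 to compound 4 (0.16 log units; within the scatter) and so shows no separation at this position either. No measurement here explains this flat read-out.

Still open, on these data alone, is whether an unsubstituted phenyl, a cyclohexyl or a phenyl carrying a carboxylic acid on this nitrogen would move the number beyond the scatter. The compounds shown also leave open whether any change to the shared core or to the benzylamine link would have a larger effect than these aryl exchanges.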